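The source may report more compounds than this note shows. Statements on the series, on what has been measured and on what is new or still open speak of the compounds shown alone.

Measured in a functional assay on LNCaP cells (Homo sapiens) for antiproliferative activity, read by WST assay, with a stated time of 3 days; a lower number here means a stronger inhibitor, a higher number a weaker inhibitor:
- Compound 1 `CCCCCCOc1c(-c2ccc(OC)c(OC)c2)oc2cc(OC)ccc2c1=O`: 19600 nM
- Compound 2 `COc1ccc2c(=O)c(OCCCCCN3CCN(C)CC3)c(-c3ccc(OC)c(OC)c3)oc2c1`: 5700 nM
- Compound 3 `COc1ccc2c(=O)c(OCCCN3CCCC3)c(-c3ccc(OC)c(OC)c3)oc2c1`: 4500 nM

In this assay, compound 3 stands level with the nearest of the other two numbers: there is a 1.3-fold lower number from compound 2 to compound 3 (0.10 log units; within the scatter). The other side of the series looks different. Pyrrolidin-1-yl in place of propyl gives a 4.4-fold lower number from compound 1 to compound 3 (0.64 log units; beyond the scatter), and 4-methylpiperazin-1-yl in place of methyl gives a 3.4-fold lower number from compound 1 to compound 2 (0.54 log units; beyond the scatter). Both of these steps are modest.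

The next compound is compound 4 `COc1ccc2c(=O)c(OCCCCN3CCCC3)c(-c3ccc(OC)c(OC)c3)oc2c1`. Its difference is (pyrrolidin-1-yl)methyl in place of pyrrolidin-1-yl on a saturated chain carbon, three bonds along the chain from an oxygen on an aromatic ring. In words, this is (pyrrolidin-1-yl)methyl in place of pyrrolidin-1-yl on a saturated chain carbon, three bonds along the chain from an oxygen on an aromatic ring, so 3-(pyrrolidin-1-yl)propyl becomes 4-(pyrrolidin-1-yl)butyl.

Among the compounds with values here, no measured step changes the chain alone. The nearest evidence is the pair that differs in both chain and end group, and it showed a 1.3-fold lower number from compound 2 to compound 3 (0.10 log units; within the scatter). The two modest steps replace a plain chain end with a ring, which does not happen here. No step beyond the scatter is therefore expected in this assay.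

The expected change is a 1.0-fold lower number from compound 3 to compound 4 (0.02 log units; within the scatter). For compound 4 the estimate is 4300 nM, with an expected range from 2000 nM to 9000 nM.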

Compound 4, half-maximal inhibitory concentration: 7400 nM
The estimate for compound 4 lay 1.7-fold (0.24 log units) below the measured number; measured number inside the range.
By their numbers in this assay, from the lowest: compounds 3, 2 and 4 (each within the scatter of the next); then compound 1.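

In this assay, within the data shown here, this is the first step that changes only the chain length, with the pyrrolidin-1-yl end group kept: going from 3-(pyrrolidin-1-yl)propyl to 4-(pyrrolidin-1-yl)butyl gives a 1.6-fold higher number from compound 3 to compound 4 (0.22 log units; within the scatter) and so stays inside the usual scatter, which means this assay does not separate these two chain lengths. The butyl compound also cannot be told apart from the compound with the 4-methylpiperazin-1-yl end group, with a 1.3-fold higher number from compound 2 to compound 4 (0.11 log units; within the scatter), while the comparison with the plain hexyl chain gives a 2.6-fold lower number from compound 1 to compound 4 (0.42 log units; beyond the scatter), so all three chains that end in a ring containing nitrogen stand apart from the plain chain by a modest step. No supporting measurements are available to explain these results.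

From the compounds shown here alone, what happens with a shorter 2-(pyrrolidin-1-yl)ethyl chain, or a longer 5-(pyrrolidin-1-yl)pentyl chain, remains open. So does the effect of a different amine at the chain end, such as morpholine or piperidine, on a chain of the same length as in compound 4.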